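Swapping a Biaryl Methoxy Group for a Benzyloxy Tail

This account rests on a few compounds, and the source may have more. Where it says the series, first, only, none or still open, it means among the compounds named here.

Compound 1 `COC(=O)c1cccc(-c2ccc([C@H]3S[C@@H](C)C(=O)Nc4c3c(C)nn4-c3ccccc3C)cc2)c1`: "not active" (no number reported)
Compound 2 `COc1ccccc1-c1ccc([C@H]2S[C@@H](C)C(=O)Nc3c2c(C)nn3-c2ccccc2C)cc1`: 1100 nM

Going by the values given here, in an assay on isolated protein for agonist activity at Bile acid receptor (Homo sapiens), read by AlphaScreen, with a stated time of 30 min (on this read-out higher numbers stand for an effect only at larger amounts of compound and lower numbers for an effect already at smaller amounts), compound 2 gives 1100 nM, the only number reported; compound 1 gives "not active" (no number reported) with no number attached. Compound 3 `Cc1ccccc1-n1nc(C)c2c1NC(=O)[C@H](C)S[C@@H]2c1ccc(OCc2ccccc2)cc1` has not yet been tested. It differs from compound 2 by one change: benzyloxy in place of 2-methoxyphenyl on an aromatic carbon. Among the compounds with values here, no measured pair in this set shows the effect of such a change, so there is no direct guide. A modest weakening is expected, as a 2.0-fold higher number from compound 2 to compound 3 (0.30 log units; within the scatter), staying close to the scatter. Compound 3 is therefore estimated at 2200 nM, within 500 nM to 9000 nM.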

Compound 3, half-maximal effective concentration: "not active" (no number reported)
The entry for compound 3 holds no number, so the estimate cannot be set against anything.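

Going by these compounds alone, compound 3 carries no number, so no step from compound 2 to compound 3 can be read. The compounds shown leave open how benzyloxy in place of 2-methoxyphenyl changes the effect. No measured evidence bears on this result.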